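A Phenyl for 2-Fluorobenzyl Swap at the Amide Nitrogen

A few compounds are considered here, and "the series" means these few. Any claim that something is new, unique, unknown or untested is made for them only; others in the source may bear on it.

Compound 1: `C=CC1=C(C(=O)NCc2ccccc2F)C(c2ccc(F)cc2)OC1`, > 100000 nM
Compound 2: `C=CC1=C(C(=O)NCC(C)C)C(c2ccc(Cl)c(Cl)c2)OC1`, > 100000 nM

Of the compounds shown here, two have so far been tested in a functional assay on SW480 cells (Homo sapiens) for cytotoxicity, read by MTT assay, with a stated time of 24 h; on this read-out higher numbers stand for weaker inhibition and lower numbers for stronger inhibition. In this assay compound 1 gives > 100000 nM, which is a limit of the assay rather than a number. Compound 2 gives > 100000 nM, which is again only a limit. Both results reflect (the limit of > 100000 nM in this assay, at which 2 of the 2 values shown sit). Neither compound therefore shows measurable cytotoxicity within the tested range, and compound 1 cannot be placed above or below compound 2 on these numbers.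

The next compound is compound 3, `C=CC1=C(C(=O)Nc2ccccc2)C(c2ccc(F)cc2)OC1`. It differs from compound 1 in one place: phenyl in place of 2-fluorobenzyl on an amide-type nitrogen. Among the measured compounds shown here, no pair of measured compounds differing in just this place exists, so the size and direction of such a change have not been seen in this assay. With both measured compounds sitting at the limit, the step expected is a number no higher from compound 1 to compound 3 (the limit leaves the size open), that is, none beyond the scatter. The estimate for compound 3 in this assay is 100000 nM, within a range from 30000 nM to 300000 nM, most likely reported again as a limit.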

Compound 3, half-maximal inhibitory concentration: > 100000 nM
Compound 3: no number, only a limit; the forecaster's own chance of this, stated with the estimate: 75%; the middle value sits exactly at the limit.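

Compound 3 gives > 100000 nM in this assay, and this is a limit, not a number. Among the compounds shown here, compound 1 also stands at a limit, so no step from compound 1 to compound 3 can be read. Still open is whether phenyl in place of 2-fluorobenzyl on the amide-type nitrogen changes cytotoxicity at all: the limit of > 100000 nM in this assay, at which 3 of the 3 values shown sit.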